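Sgk1 inhibitors: changing the ether side chain

This account rests on a few compounds, and the source may have more. Where it says the series, first, only, none or still open, it means among the compounds named here.

Measured compounds:
compound 1 `CCOc1nc(-c2ccc(NS(=O)(=O)c3cc(Cl)ccc3F)cc2)nc2[nH]nc(C)c12`, 23 nM
compound 2 `Cc1n[nH]c2nc(-c3ccc(NS(=O)(=O)c4cc(Cl)ccc4F)cc3)nc(OCCC(=O)N(C)C)c12`, 15 nM
compound 3 `Cc1n[nH]c2nc(-c3ccc(NS(=O)(=O)c4cc(Cl)ccc4F)cc3)nc(OCC3CNCCO3)c12`, 2 nM

In an assay for inhibition of serine/threonine-protein kinase Sgk1 (Homo sapiens), with stated times of 30 min and 60 min, in the presence of a further agent that is not named here (a lower number here means a stronger inhibitor, a higher number a weaker inhibitor), compound 3 gives the lowest of the three numbers; its steps to the others, a 12-fold lower number from compound 1 to compound 3 (1.06 log units; beyond the scatter) and a 7.5-fold lower number from compound 2 to compound 3 (0.88 log units; beyond the scatter), both lie beyond the scatter, while a 1.5-fold lower number from compound 1 to compound 2 (0.19 log units; within the scatter) does not. Compound 4 `Cc1n[nH]c2nc(-c3ccc(NS(=O)(=O)c4cc(Cl)ccc4F)cc3)nc(OC3CC(C)(C)NC(C)(C)C3)c12` carries 2,2,6,6-tetramethylpiperidin-4-yl in place of (morpholin-2-yl)methyl on an oxygen on an aromatic ring. Both larger steps concern the same side chain on the shared core, and both ran toward the ring-bearing chain of compound 3. Compound 4 keeps a saturated ring with one hydrogen-bond donor there, so no step beyond the scatter is expected in this assay, at most a small loss; the estimated step is a 2.0-fold higher number from compound 3 to compound 4 (0.30 log units; within the scatter). Compound 4 is thus expected to give about 4 nM, between 1 nM and 20 nM.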

Compound 4, half-maximal inhibitory concentration: 3 nM
Estimate against measurement, compound 4: 1.3-fold (0.12 log units) above; the range from low to high includes it.
By their numbers in this assay, from the lowest: compounds 3 and 4 (each within the scatter of the next); then compounds 2 and 1 (each within the scatter of the next).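

In this assay, the change from (morpholin-2-yl)methoxy to (2,2,6,6-tetramethylpiperidin-4-yl)oxy gives a 1.5-fold higher number from compound 3 to compound 4 (0.18 log units; within the scatter), so a low number at this position does not depend on the morpholine ring oxygen or on the methylene link. The advantage of compound 3 over the ethyl and amide chains also appears with this second ring, with a 7.7-fold lower number from compound 1 to compound 4 (0.88 log units; beyond the scatter) and a 5.0-fold lower number from compound 2 to compound 4 (0.70 log units; beyond the scatter). No available data explain these results. The compounds shown leave open whether the ring nitrogen is needed, which a cyclohexyl group would test. They also leave open what the four methyl groups contribute, which a plain piperidin-4-yl group would show.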